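Swapping Chloro for Methylpiperazinyl on the Sulfonyl Aryl

The source may hold more compounds than are shown below. What is called first, only, known or untested is meant among the compounds shown, and "the series" means these compounds.

Compound 1, `COc1cc(N)c(Cl)cc1C(=O)CCC1CCN(CCNS(=O)(=O)c2cc(Br)ccc2Br)CC1`: 16%
Compound 2, `COc1ccc(S(=O)(=O)NCCN2CCC(CCC(=O)c3cc(Cl)c(N)cc3OC)CC2)cc1Cl`: 20%
Compound 3, `COc1cc(N)c(Cl)cc1C(=O)CCC1CCN(CCNS(=O)(=O)c2ccc(N)c(Br)c2)CC1`: 39%

In an assay on HEK293 cells for displacement of a labelled ligand from 5-hydroxytryptamine receptor 6 (Homo sapiens), with a stated time of 60 min, tested at 0.01 uM, in the presence of a further agent that is not named here (a higher number here means a stronger effect of the compound at the concentration tested, a lower number a weaker effect), compound 2 stands second of the three numbers: one of its steps is close, a number 4 percentage points higher from compound 1 to compound 2 (within the scatter), and the other clearly apart, a number 19 percentage points higher from compound 2 to compound 3 (beyond the scatter). Compound 4, `COc1cc(N)c(Cl)cc1C(=O)CCC1CCN(CCNS(=O)(=O)c2ccc(OC)c(N3CCN(C)CC3)c2)CC1`, differs from compound 2 in one place: 4-methylpiperazin-1-yl in place of chloro on an aromatic carbon. Every measured step changes the aryl group on the sulfonyl sulfur: a number 4 percentage points higher from compound 1 to compound 2 (within the scatter), a number 23 percentage points higher from compound 1 to compound 3 (beyond the scatter) and a number 19 percentage points higher from compound 2 to compound 3 (beyond the scatter). None of them brings in 4-methylpiperazin-1-yl, so the bearing is only indirect; the steps show that aryl changes can move the read-out modestly. Compound 4 is therefore expected to show a small rise at most, a number 6 percentage points higher from compound 2 to compound 4 (within the scatter). The estimate for compound 4 is 26%, with a range from 8% to 46%.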

Compound 4, a percentage reported as inhibition, at one concentration (the size of the read-out at that concentration, not a potency): 4%
Compound 4: the middle estimate sits 22 percentage points above what was measured; the whole stated range lies above it.
By their numbers in this assay, from the lowest: compound 4; then compounds 1 and 2 (each within the scatter of the next); then compound 3.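

Replacing chloro with 4-methylpiperazin-1-yl gives a number 16 percentage points lower from compound 2 to compound 4 (beyond the scatter) in this assay, so this place, ortho to a methoxy group, responds to its substituent. The earlier steps shown here exchanged the whole aryl group on the sulfonyl sulfur, while this one changes a single place, and here the larger group with its non-aromatic ring goes with a lower number. Nothing available explains this drop.

From the compounds shown here alone, it remains open whether a fluoro, a dimethylamino or an unsubstituted piperazin-1-yl group at this place would behave like chloro or like 4-methylpiperazin-1-yl. Going by these compounds, it is also open whether the same exchange would lower the read-out on another sulfonyl aryl group.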